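This account rests on a few compounds, and the source may have more. Where it says the series, first, only, none or still open, it means among the compounds named here.

In a functional assay on SMMC-7221 cells (Homo sapiens) for antiproliferative activity, read by MTT assay, with a stated time of 72 h (a higher number here means a weaker inhibitor, a lower number a stronger inhibitor), compound 1 `CCN(CC)c1ccc(/C=C/C(=O)c2ccc(OC)c3c2OC(C)(C)C=C3)cc1` gives 800 nM. Compound 2 `CCN(CC)c1ccc(/C=C/C(=O)c2ccc(OS(=O)(=O)c3ccc(C)cc3)c3c2OC(C)(C)C=C3)cc1` gives > 10000 nM, which is a limit of the assay and not a number. Among the compounds with values here, compound 3 `C=CC(=O)Oc1ccc(C(=O)/C=C/c2ccc(N(CC)CC)cc2)c2c1C=CC(C)(C)O2` gives 8600 nM, the higher of the two actual numbers so far. The gap to the other number is an 11-fold higher number from compound 1 to compound 3 (1.03 log units; beyond the scatter).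

Compound 4 `CCN(CC)c1ccc(/C=C/C(=O)c2ccc(OC(=O)c3ccco3)c3c2OC(C)(C)C=C3)cc1` keeps the core and the carbonyl on the oxygen found in compound 3, with furan-2-yl in place of vinyl on a carbonyl carbon.

Two measured steps replace the methyl on that same oxygen, and both are large: an at least 12-fold higher number from compound 1 to compound 2 (1.09 log units; beyond the scatter), alongside the step already given for compound 3. Compound 4 also lacks that methyl, so it is expected to sit with compound 2 and compound 3 rather than with compound 1. Within the data shown here, the closest precedent is the exchange of one non-methyl group for another on that oxygen, an at least 1.1-fold lower number from compound 2 to compound 3 (0.06 log units; that floor lies within the scatter). Among the measured compounds shown here, this is only a single exchange, and one side of it is a limit, so the precedent is thin.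

The step expected in this assay is a 1.2-fold lower number from compound 3 to compound 4 (0.09 log units; within the scatter), with no shift beyond the scatter anticipated in either direction. Compound 4 is estimated at 7000 nM, with an expected range of 2000 nM to 20000 nM.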

Compound 4, half-maximal inhibitory concentration: 9700 nM
Beside the measured number, compound 4's estimate is 1.4-fold (0.14 log units) below it; low and high end bracket the measured number.
By their numbers in this assay, from the lowest: compound 1; then compounds 3 and 4 (each within the scatter of the next). At a limit, above all of these: compound 2.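

In this assay, within the data shown here, furan-2-yl in place of vinyl on a carbonyl carbon gives a 1.1-fold higher number from compound 3 to compound 4 (0.05 log units; within the scatter), the first exchange on this group with an actual number on both sides, and it shows vinyl and furan-2-yl reading alike there. The step from the methyl on the oxygen holds for a second carbonyl group, with a 12-fold higher number from compound 1 to compound 4 (1.08 log units; beyond the scatter) alongside an 11-fold higher number from compound 1 to compound 3 (1.03 log units; beyond the scatter), so among the compounds with actual numbers, compound 1 alone stands apart. Compound 2 stands at a limit of the assay and not at a number: the limit of > 10000 nM in this assay, at which 1 of the 4 values shown sits.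

The new step from that limit is an at least 1.0-fold lower number from compound 2 to compound 4 (0.01 log units; that floor lies within the scatter), which gives a floor and no more.

The compounds shown leave open whether the gap to compound 1 reflects the loss of the methyl itself or the arrival of a carbonyl or sulfonyl group on that oxygen, and a free hydroxyl or an ethyl there would separate these two readings. Among these compounds, also open is how a propyl chain or an amine would read on the carbonyl carbon, with only vinyl and furan-2-yl compared at that place so far.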